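A few compounds are considered here, and "the series" means these few. Any claim that something is new, unique, unknown or untested is made for them only; others in the source may bear on it.

For the measured compounds named here, compound 2 `C(=N/N(Cc1ccccc1)Cc1ccccc1)\c1cccnc1` gives 3700 nM in an assay on liver (Sus scrofa) for inhibition of glucose-6-phosphatase catalytic subunit 1 (Homo sapiens), using microsomes (on this read-out lower numbers stand for stronger inhibition and higher numbers for weaker inhibition), the highest of the two numbers measured so far; its nearest neighbour is compound 1 `C(=N/N(Cc1ccccc1)Cc1ccccc1)\c1ccco1`, which in this assay gives 1100 nM. Going by the values given here, the one measured step, a 3.4-fold higher number from compound 1 to compound 2 (0.53 log units; beyond the scatter), bears directly on the move to compound 3 `Clc1ccc(/C=N/N(Cc2ccccc2)Cc2ccccc2)s1`, which differs from compound 2 by 5-chlorothiophen-2-yl in place of pyridin-3-yl on a carbon with a double bond to nitrogen. Since a five-membered aromatic ring returns at that carbon, the step of a 4.6-fold lower number from compound 2 to compound 3 (0.67 log units; beyond the scatter) is expected to run back toward the lower number of compound 1. Compound 3 is therefore estimated at 800 nM, with a range of 300 nM to 2500 nM.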

Compound 3, half-maximal inhibitory concentration: 170 nM
Compound 3: the middle estimate sits 4.7-fold (0.67 log units) above what was measured; the measured number lies below the stated range.
By their numbers in this assay, from the lowest: compound 3; then compound 1; then compound 2.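

At the carbon with a double bond to nitrogen, 5-chlorothiophen-2-yl improves on both earlier groups: replacing pyridin-3-yl gives a 22-fold lower number from compound 2 to compound 3 (1.34 log units; beyond the scatter) and replacing furan-2-yl gives a 6.5-fold lower number from compound 1 to compound 3 (0.81 log units; beyond the scatter) in a further gain. The two five-membered aromatic rings therefore differ clearly from each other, so having such a ring at this carbon does not alone set the number. No measurement shown accounts for these gaps. On these data alone, what an unsubstituted thiophen-2-yl or a 5-bromothiophen-2-yl would give stays open, leaving the shares of the sulfur and the chlorine unseparated.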